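A few compounds are considered here, and "the series" means these few. Any claim that something is new, unique, unknown or untested is made for them only; others in the source may bear on it.

Measured so far:
compound 1, `CCC(C)C(NC(=O)n1nnc2ccccc21)C(=O)NC(c1ccccc1)c1ccccc1`: 55300 nM
compound 2, `O=C1NC(c2ccccc2)C(=O)N1C1CCCC1`: > 100000 nM
compound 3, `CC(C)C1NC(=O)N(C2CCCCC2)C1=O`: 100000 nM

In a functional assay on HEp-2 cells (Homo sapiens) for inhibition (a higher number here means a weaker inhibitor, a lower number a stronger inhibitor), compound 1 gives 55300 nM. Compound 3 gives 100000 nM. For compound 2 the result is only a limit of the assay, > 100000 nM, so it sits at the limit of > 100000 nM in this assay, at which 1 of the 3 values shown sits, and no number is known for it. Compound 4, `CC(C)C1NC(=O)N(C2CCCC2)C1=O`, is not yet measured; against compound 2 it shows one change: isopropyl in place of phenyl on a saturated ring carbon. Going by the values given here, no step between measured compounds that differ in one place is available here. Compound 3 also carries isopropyl and gives 100000 nM, so in this assay no step beyond the scatter is expected. Compound 4 is expected at 100000 nM, with a range from 40000 nM to 250000 nM. This estimate means an expected step of a number no higher from compound 2 to compound 4 (the limit leaves the size open).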

Compound 4, half-maximal inhibitory concentration: 98000 nM
Beside the measured number, compound 4's estimate is 1.0-fold (0.01 log units) above it; the range from low to high includes it.
By their numbers in this assay, from the lowest: compounds 1, 4 and 3 (each within the scatter of the next).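

With isopropyl in place of phenyl on a saturated ring carbon, this assay shows an at least 1.0-fold lower number from compound 2 to compound 4 (0.00 log units; that floor lies within the scatter), which gives this position its first number with cyclopentyl present. Compound 2 remains a limit of the assay, not a number, so the size of the step stays unread: the limit of > 100000 nM in this assay, at which 1 of the 4 values shown sits.

Compound 3 gives 100000 nM and compound 4 gives 98000 nM, within the scatter of each other, so cyclopentyl and cyclohexyl do not separate with isopropyl in place.

Open, going by these compounds, is whether an amine or a carboxylic acid on this ring carbon would shift the number beyond the scatter from compound 4.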